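A few compounds are considered here, and "the series" means these few. Any claim that something is new, unique, unknown or untested is made for them only; others in the source may bear on it.

Compound 3, `COc1cc(-n2cnc3ccc(-c4ccc([N+](=O)[O-])cc4)cc32)cc(OC)c1OC`, gives 740 nM in a functional assay on MCF7 cells (Homo sapiens) for antiproliferative activity, read by MTT assay, with a stated time of 72 h (on this read-out higher numbers stand for weaker inhibition and lower numbers for stronger inhibition), and sits at the lowest of the two numbers shown. Compound 1, `COc1ccccc1-c1ccc2ncn(-c3cc(OC)c(OC)c(OC)c3)c2c1`, gives 1750 nM. Compound 2, `COc1cc(-n2cnc3ccc(-c4ccccc4Cl)cc32)cc(OC)c1OC`, reaches only a limit of the assay at > 10000 nM. Compound 4, `COc1ccc(-c2ccc3ncn(-c4cc(OC)c(OC)c(OC)c4)c3c2)cc1`, has not been measured; it differs from compound 3 by methoxy in place of nitro on an aromatic carbon. The measured steps bear on this change only at one remove: a 2.4-fold lower number from compound 1 to compound 3 (0.37 log units; beyond the scatter) shows the nitro-bearing phenyl giving the lower number, while an at least 5.7-fold higher number from compound 1 to compound 2 (0.75 log units; beyond the scatter) and an at least 13-fold lower number from compound 2 to compound 3 (1.13 log units; beyond the scatter) show that the group on that phenyl ring can shift the number by a wide margin, though the chloro compound gives only a limit (the limit of > 10000 nM in this assay, at which 1 of the 3 values shown sits). Since the methoxy-bearing phenyl of compound 1 gives a higher number than compound 3, a modest rise is expected on replacing nitro with methoxy, a 2.2-fold higher number from compound 3 to compound 4 (0.33 log units; beyond the scatter). Compound 4 is therefore estimated at 1600 nM, with a range from 600 nM to 4500 nM.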

Compound 4, half-maximal inhibitory concentration: 210 nM
Compound 4: the middle estimate sits 7.6-fold (0.88 log units) above what was measured, outside the stated range (below it).
By their numbers in this assay, from the lowest: compound 4; then compound 3; then compound 1. At a limit, above all of these: compound 2.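

In this assay, with the group para to a large group, methoxy gives a lower number than nitro: a 3.5-fold lower number from compound 3 to compound 4 (0.55 log units; beyond the scatter). The place of the methoxy also counts, since 4-methoxyphenyl in place of 2-methoxyphenyl gives an 8.3-fold lower number from compound 1 to compound 4 (0.92 log units; beyond the scatter), whereas the earlier comparison of compound 1 with compound 3 changed group and place together. The step from the 2-chlorophenyl compound, an at least 47-fold lower number from compound 2 to compound 4 (1.67 log units; beyond the scatter), starts from a limit and gives only a bound: the limit of > 10000 nM in this assay, at which 1 of the 4 values shown sits.

The compounds shown leave open whether the lower number is particular to methoxy or extends to other groups at this place, such as an amine, a hydroxyl or a longer ether chain. They also leave open whether this order holds in any cell line other than this one.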